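The compounds below may be only part of what the source reports. "The series", "measured", "known", "first", "only" and "open" are said of these compounds alone.

In an assay on isolated protein for inhibition of biotin--protein ligase (Homo sapiens), read by scintillation counting, with a stated time of 10 min (on this read-out higher numbers stand for weaker inhibition and lower numbers for stronger inhibition), two compounds of this series have been measured, both built on the shared core of compound 1 `O=C1N[C@H]2[C@H](CS[C@H]2CCCCCc2cn(Cc3cccc(O)c3)nn2)N1`. Compound 1 reaches only the limit of this assay, > 16000 nM. Compound 2 `O=C1N[C@H]2[C@H](CS[C@H]2CCCCCc2cn(Cc3ccccc3Br)nn2)N1` likewise reaches only the limit of this assay, > 16000 nM. Within the data shown here, the step between them, a step that the two limits leave unreadable from compound 1 to compound 2, therefore cannot be sized; the two limits the limit of > 16000 nM in this assay, at which 2 of the 2 values shown sit, show only that neither compound inhibits within the range that this assay resolves. Compound 3 `O=C1N[C@H]2[C@H](CS[C@H]2CCCCCc2cn(Cc3ccc(I)cc3)nn2)N1` continues from compound 2 by the change (4-iodophenyl in place of 2-bromophenyl on a saturated chain carbon bound to an aromatic nitrogen). Among the measured compounds shown here, no measured step bears on this change beyond the unreadable one from compound 1 to compound 2, which tells nothing about direction or size. Compound 2 sits at the limit > 16000 nM in this assay. Compound 3 is therefore expected to stay at that limit as well, so the step that the limit leaves unreadable from compound 2 to compound 3 is estimated to be none that this assay could read. Compound 3 is thus estimated at 30000 nM, within 10000 nM to 100000 nM, and will most likely be reported as a limit once more.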

Compound 3, inhibition constant: > 16000 nM
Compound 3: only a limit was reported (the forecaster's own chance of this, stated with the estimate: 85%); the middle value is on the limit's open side.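

In this assay compound 3, like compound 1 and compound 2, gives only a limit, so neither of its steps from those two compounds can be read: the limit of > 16000 nM in this assay, at which 3 of the 3 values shown sit.

The compounds shown leave open whether the 3-hydroxyphenyl, 2-bromophenyl and 4-iodophenyl compounds differ at all in inhibition, and what change to the shared core would give a measurable value in this assay.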